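Cytotoxicity Limits Across Three Aryl Variants

This account rests on a few compounds, and the source may have more. Where it says the series, first, only, none or still open, it means among the compounds named here.

Compound 1 (`CC(C)N(Cc1cccc(OCCCCCC(=O)O)c1)C(=O)c1ccc(-c2ccco2)cc1`): in an ADME assay on Raji cells (Homo sapiens) for cytotoxicity, read by CellTiter-Glo and resazurin assay, with a stated time of 72 h (a lower number here means that less compound is needed, a higher number that more compound is needed for the effect), compound 1 gives > 26000 nM, which is a limit of the assay rather than a number.
Compound 2 (`CC(C)N(Cc1cccc(OCCCCCC(=O)O)c1)C(=O)c1ccc(-c2ccc3c(c2)OCCO3)cc1`): in this assay compound 2 gives > 21900 nM, again a limit and not a number.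
Compound 3 (`CC(C)N(Cc1cccc(OCCCCCC(=O)O)c1)C(=O)c1ccc(-c2c[nH]c3ccccc23)cc1`): in this assay compound 3 gives > 26000 nM, also a limit.

Compound 3 therefore stands at the limit of > 26000 nM in this assay, at which 2 of the 3 values shown sit, while the remaining value sits at the limit of > 21900 nM in this assay, at which 1 of the 3 values shown sits. On these data alone, none of the three compounds reached a measurable effect, so the comparisons among them stay open: a step that the two limits leave unreadable from compound 1 to compound 2, a step that the two limits leave unreadable from compound 1 to compound 3 and a step that the two limits leave unreadable from compound 2 to compound 3. The change from compound 3 to compound 4 (`COc1ccc(F)c(-c2ccc(C(=O)N(Cc3cccc(OCCCCCC(=O)O)c3)C(C)C)cc2)c1`) is 2-fluoro-5-methoxyphenyl in place of 1H-indol-3-yl on an aromatic carbon. Every measured step on this aromatic position, whether to a furan-2-yl, a 2,3-dihydro-1,4-benzodioxin-6-yl or a 1H-indol-3-yl, ended at a limit, so no direction or size can be read from them, and the expectation for compound 4 in this assay is no step beyond the scatter, expressed as a number no higher from compound 3 to compound 4 (the limit leaves the size open). Compound 4 is accordingly expected to give about 26000 nM, within a range from 10000 nM to 60000 nM, most likely reported again only as a limit.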

Compound 4, half-maximal effective concentration: > 26000 nM
Compound 4: a limit, no number; the forecaster's own chance of this, stated with the estimate: 80%; the middle value sits exactly at the limit.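

In this assay compound 4 gives > 26000 nM, a limit and not a number, so its steps from compound 1, compound 2 and compound 3 cannot be read. The compounds shown leave open whether any group on this aromatic carbon changes the concentration needed for the effect, and what that concentration would be.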